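The source may hold more compounds than are shown below. What is called first, only, known or untested is meant among the compounds shown, and "the series" means these compounds.

Three compounds sharing one core differ only in the aromatic ring carried on the triple-bonded carbon. Compound 1 `Cc1cccc(C#Cc2ccc3c(n2)CCN(C(C)C)C3=O)c1` carries a 3-methylphenyl there, and in a functional assay on HEK293 cells for negative allosteric modulation of metabotropic glutamate receptor 5 (Homo sapiens), read by FLIPR and calcium flux (a higher number here means a weaker inhibitor, a lower number a stronger inhibitor), compound 1 gives 4.8 nM. Compound 2 `CC(C)N1CCc2nc(C#Cc3ccccc3Cl)ccc2C1=O` carries a 2-chlorophenyl, and in this assay compound 2 gives 2520 nM. Compound 3 `CC(C)N1CCc2nc(C#Cc3ccc(Cl)cc3)ccc2C1=O` carries a 4-chlorophenyl, and in this assay compound 3 gives 4230 nM, the highest number of the three. The steps are a 530-fold higher number from compound 1 to compound 2 (2.72 log units; beyond the scatter) and an 880-fold higher number from compound 1 to compound 3 (2.95 log units; beyond the scatter); between the two chlorophenyl compounds there is a 1.7-fold higher number from compound 2 to compound 3 (0.22 log units; within the scatter).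

Compound 4 `CC(C)N1CCc2nc(C#Cc3cccs3)ccc2C1=O` is not yet measured. It differs from compound 3 in one place: thiophen-2-yl in place of 4-chlorophenyl on a triple-bonded carbon. All three measured steps bear on this position, since each swaps the ring on the triple-bonded carbon, and they show that this ring matters greatly: the 3-methylphenyl gave a low number, while either chlorophenyl gave a high one. A thiophen-2-yl has no chlorine and is a five-membered rather than six-membered ring, so the outcome in this assay is uncertain between those extremes. Compound 4 is expected to give 300 nM, within a range from 30 nM to 3000 nM. The expected step is a 14-fold lower number from compound 3 to compound 4 (1.15 log units; beyond the scatter), toward a stronger inhibitor, though the range is wide enough to allow no change beyond the scatter.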

Compound 4, half-maximal inhibitory concentration: 45 nM
Compound 4: the middle estimate sits 6.7-fold (0.82 log units) above what was measured; the measured number falls inside the stated range.
By their numbers in this assay, from the lowest: compound 1; then compound 4; then compounds 2 and 3 (each within the scatter of the next).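

Placing thiophen-2-yl on the triple-bonded carbon gives a 94-fold lower number from compound 3 to compound 4 (1.97 log units; beyond the scatter) in this assay, and measured against the other chlorophenyl it gives a 56-fold lower number from compound 2 to compound 4 (1.75 log units; beyond the scatter), so a ring with five atoms and a sulfur in place of a chlorophenyl is accepted here and reads far lower. The position therefore does not divide simply into the 3-methylphenyl on one side and everything else on the other: the thiophen-2-yl still falls short of the 3-methylphenyl, with a 9.4-fold higher number from compound 1 to compound 4 (0.97 log units; beyond the scatter), and so occupies a clear middle level among the four rings. Nothing measured here accounts for these differences.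

The single change from 4-chlorophenyl to thiophen-2-yl alters ring size, adds a sulfur and removes a chlorine all at once, and the compounds shown cannot separate these three changes. They also leave open how a furan ring or a pyridine ring would read at this position, and whether a methyl group added to the thiophen-2-yl would bring the number closer to that of compound 1.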